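The compounds below may be only part of what the source reports. "The series", "measured", "known", "first", "only" and "open" are said of these compounds alone.

Compound 1, `CCCCCCCCn1nc(-c2cccnc2)c2ccccc2c1=O`, is the starting point. In a functional assay (trachea) with Cavia porcellus as the target (on this read-out lower numbers stand for stronger inhibition and higher numbers for weaker inhibition), compound 1 gives 21900 nM, the highest of the two numbers measured here. Its nearest neighbour is compound 2, `O=c1c2ccccc2c(-c2cccnc2)nn1CCSc1ccccc1`, which in this assay gives 9120 nM; the step between them is a 2.4-fold lower number from compound 1 to compound 2 (0.38 log units; beyond the scatter). Compound 3, `O=C(O)CCCn1nc(-c2cccnc2)c2ccccc2c1=O`, has no number at all. For compound 3 the read-out stops at the limit of > 100000 nM in this assay, at which 1 of the 3 values shown sits, a limit of the assay. In this assay compound 3 is recorded as > 100000 nM, a limit rather than a number. The steps that run into this limit are an at least 4.5-fold higher number from compound 1 to compound 3 (0.65 log units; beyond the scatter) and an at least 10-fold higher number from compound 2 to compound 3 (1.04 log units; beyond the scatter). Compound 4, `CC(C)NC(=O)CCCn1nc(-c2cccnc2)c2ccccc2c1=O`, has not yet been measured. It differs from compound 1 by isopropylcarbamoyl in place of pentyl on a saturated chain carbon, three bonds along the chain from an aromatic nitrogen. Among the measured compounds shown here, the measured step that bears most on this is the one into compound 3, the only change here in which pentyl leaves this place, and it rose beyond the scatter. Compound 4 is therefore expected to give 60000 nM, between 20000 nM and 150000 nM, a step of a 2.7-fold higher number from compound 1 to compound 4 (0.44 log units; beyond the scatter).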

Compound 4, half-maximal inhibitory concentration: 64600 nM
Beside the measured number, compound 4's estimate is 1.1-fold (0.03 log units) below it; low and high end bracket the measured number.
By their numbers in this assay, from the lowest: compound 2; then compound 1; then compound 4. At a limit, above all of these: compound 3.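

Compound 4 shows that a chain ending in isopropylcarbamoyl, on a saturated chain carbon three bonds along the chain from an aromatic nitrogen, still gives a real number in this assay, with a 2.9-fold higher number from compound 1 to compound 4 (0.47 log units; beyond the scatter). Set against the phenylsulfanyl chain the change is larger, a 7.1-fold higher number from compound 2 to compound 4 (0.85 log units; beyond the scatter), so compound 2 keeps the lowest number of the series. Compound 3 is recorded only as a limit of the assay: the limit of > 100000 nM in this assay, at which 1 of the 4 values shown sits. Against that limit the change is an at least 1.5-fold lower number from compound 3 to compound 4 (0.18 log units; that floor lies within the scatter), a floor within the scatter, so it settles no order.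

The compounds shown leave open whether the amide hydrogen matters, which a dimethylamide at the chain end would test, and how an amine there would compare. They also leave open whether a shorter or longer chain carrying the same isopropylcarbamoyl end would bring the number closer to that of compound 2.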